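The source may report more compounds than this note shows. Statements on the series, on what has been measured and on what is new or still open speak of the compounds shown alone.

Measured in a functional assay on DU-145 cells (Homo sapiens) for antiproliferative activity, read by sulforhodamine B assay, with a stated time of 72 h; on this read-out lower numbers stand for stronger inhibition and higher numbers for weaker inhibition:
- compound 1 `Cc1cc(C)nc(NS(=O)(=O)c2ccc(Nc3nncc4ccccc34)cc2)n1`: 7.8 nM
- compound 2 `O=S(=O)(Nc1nccs1)c1ccc(Nc2nncc3ccccc23)cc1`: 24 nM
- compound 3 `O=C1CS/C(=N/Nc2nncc3ccccc23)N1`: 67 nM

Compound 2 stands in the middle of these numbers, with compound 1 lower and compound 3 higher, both gaps beyond the scatter. Compound 4 `Cc1cc(NS(=O)(=O)c2ccc(Nc3nncc4ccccc34)cc2)no1` carries 5-methyl-1,2-oxazol-3-yl in place of 1,3-thiazol-2-yl on a sulfonamide nitrogen. Among the compounds with values here, only one measured step changes this place: a 3.1-fold higher number from compound 1 to compound 2 (0.49 log units; beyond the scatter), a modest step beyond the scatter. Within the data shown here, no measured step covers this exchange itself, so the direction stays open. A smaller step is expected in this assay, probably none beyond the scatter. The expected step is a 1.2-fold lower number from compound 2 to compound 4 (0.08 log units; within the scatter). Compound 4 is estimated at 20 nM, with an expected range of 7 nM to 60 nM.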

Compound 4, half-maximal inhibitory concentration: 35 nM
Beside the measured number, compound 4's estimate is 1.8-fold (0.24 log units) below it; measured number inside the range.
By their numbers in this assay, from the lowest: compound 1; then compounds 2, 4 and 3 (each within the scatter of the next, the first and the last beyond it).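

On a sulfonamide nitrogen, 5-methyl-1,2-oxazol-3-yl can replace 1,3-thiazol-2-yl without a change beyond the scatter: a 1.5-fold higher number from compound 2 to compound 4 (0.16 log units; within the scatter). The 4,6-dimethylpyrimidin-2-yl group of compound 1 now has a gap beyond the scatter to two different five-membered aromatic rings, with a 4.5-fold higher number from compound 1 to compound 4 (0.65 log units; beyond the scatter) adding to the earlier step to compound 2. No evidence on hand accounts for these differences.

It remains open whether the two methyl groups on the pyrimidin-2-yl ring matter, since the unsubstituted pyrimidin-2-yl group is not among these compounds. A phenyl ring on the same nitrogen is also untested in this set.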